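This account rests on a few compounds, and the source may have more. Where it says the series, first, only, none or still open, it means among the compounds named here.

Of the compounds shown here, three sharing one core have been read in an ADME assay on microsomes from liver (Rattus norvegicus) for metabolic stability (a higher number here means that the compound lasts longer, a lower number that the compound disappears faster), differing only in the group on an aromatic carbon of a six-membered aromatic ring of carbon only. Compound 1 `COc1cc(OCc2cccc(-c3ccc(C(F)(F)F)cn3)c2)c2cc(-c3cn4nc(OC)sc4n3)oc2c1` gives > 2 h, which is a limit of the assay and not a number. Compound 2 `COc1cc(OCc2cccc(-c3ccc(OC)nc3)c2)c2cc(-c3cn4nc(OC)sc4n3)oc2c1` gives 0.633 h, and compound 3 `COc1cc(OCc2cccc(-c3cnc(OC)nc3)c2)c2cc(-c3cn4nc(OC)sc4n3)oc2c1` gives 1.03 h. These two numbers stand level, with a 1.6-fold higher number from compound 2 to compound 3 (0.21 log units; within the scatter). Against the limit, the picture is mixed: an at least 3.1-fold lower number from compound 1 to compound 2 (0.49 log units; beyond the scatter), whereas an at least 1.9-fold lower number from compound 1 to compound 3 (0.28 log units; that floor lies within the scatter).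

Compound 4 `COc1cc(OCc2cccc(-c3cnc(OC)cn3)c2)c2cc(-c3cn4nc(OC)sc4n3)oc2c1` keeps the atoms of compound 3 but joins them differently: 5-methoxypyrazin-2-yl in place of 2-methoxypyrimidin-5-yl on an aromatic carbon. Among the compounds with values here, the closest precedent is the exchange of one methoxy-bearing ring for another, seen in compound 3 with 1.03 h and compound 2 with 0.633 h, a change that stayed within the scatter in this assay. The two steps away from compound 1 replace a trifluoromethyl-bearing ring and say less about this exchange. No step beyond the scatter is therefore expected, and no direction can be assigned. The estimated step is a 1.1-fold lower number from compound 3 to compound 4 (0.06 log units; within the scatter). Compound 4 is expected to read 0.9 h, with an estimated range of 0.45 h to 1.8 h.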

Compound 4, half-life: 1.62 h
Beside the measured number, compound 4's estimate is 1.8-fold (0.26 log units) below it; the range from low to high includes it.
By their numbers in this assay, from the lowest: compounds 2, 3 and 4 (each within the scatter of the next, the first and the last beyond it). At a limit, above all of these: compound 1.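

Rejoining the same atoms as a 5-methoxypyrazin-2-yl group in place of the 2-methoxypyrimidin-5-yl group gives a 1.6-fold higher number from compound 3 to compound 4 (0.20 log units; within the scatter), so in this assay this exchange does not separate the two compounds. Within the data shown here, the new group does stand apart from the 6-methoxypyridin-3-yl group, with a 2.6-fold higher number from compound 2 to compound 4 (0.41 log units; beyond the scatter); this is the first step beyond the scatter among the methoxy-bearing rings at this position, which the earlier pair of compound 2 and compound 3 did not show. Compound 1 is held at a limit of the assay, not a number, and the step that results is an at least 1.2-fold lower number from compound 1 to compound 4 (0.09 log units; that floor lies within the scatter), so compound 4, like compound 3 and unlike compound 2, is not shown to fall short of the 5-(trifluoromethyl)pyridin-2-yl group.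

On these data alone, how far compound 1 really lies from compound 4 stays open, as the reading of compound 1 gives only a floor for that gap. Also open, as far as these compounds go, is how this position would read with an amine, a carboxylic acid or a longer alkoxy chain on the ring in place of the methoxy group.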